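Turning the amide around on the methylamino series

A few compounds are considered here, and "the series" means these few. Any claim that something is new, unique, unknown or untested is made for them only; others in the source may bear on it.

Three compounds share one core, read in a functional assay on SW480 cells (Homo sapiens) for inhibition, read by luminescence and resazurin assay, with a stated time of 3 days; on this read-out higher numbers stand for weaker inhibition and lower numbers for stronger inhibition. Compound 3 `CNc1nc(NCc2ccc(C(=O)Nc3ccc(F)cc3)cc2)c2ccccc2n1` gives 4100 nM, the lowest of the two plain numbers shown. Compound 1 `CN(C)CCCNc1nc(NCc2ccc(NC(=O)c3ccc(F)cc3)cc2)c2ccccc2n1` gives 14000 nM, a weaker result. Compound 2 `CNc1nc(NCc2ccc(NC(=O)c3ccncc3)cc2)c2ccccc2n1` reaches only the limit of this assay, > 20000 nM, so no number is known for it.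

Compound 4 `CNc1nc(NCc2ccc(NC(=O)c3ccc(F)cc3)cc2)c2ccccc2n1` is still to be measured. It differs from compound 3 in one place: ((4-fluorophenyl)carbonyl)amino in place of (4-fluorophenyl)carbamoyl on an aromatic carbon. The same atoms are kept, but the amide is reversed at the place described above.

Among the measured compounds shown here, only one measured step touches this change, and only partly: an at least 4.8-fold lower number from compound 2 to compound 3 (0.68 log units; beyond the scatter). That step changes the amide orientation and the ring on it at once, so it cannot separate the two. Compound 1 carries the same ((4-fluorophenyl)carbonyl)amino group that compound 4 will carry, but with a different group on the core, so its value only shows that this orientation can sit well above compound 3. Compound 4 is therefore expected to give a number some way weaker than compound 3, a 3.9-fold higher number from compound 3 to compound 4 (0.59 log units; beyond the scatter), with a real chance of only a limit.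

The estimate for compound 4 is 16000 nM, within a range from 6000 nM to 40000 nM.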

Compound 4, half-maximal inhibitory concentration: 2000 nM
The estimate for compound 4 lay 8.0-fold (0.90 log units) above the measured number; measured number below the stated range.
By their numbers in this assay, from the lowest: compound 4; then compound 3; then compound 1. At a limit, above all of these: compound 2.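

The reversed amide turns out to be no loss on this core. In this assay, with the same atoms joined differently at this one place, the result is a 2.1-fold lower number from compound 3 to compound 4 (0.31 log units; beyond the scatter), so ((4-fluorophenyl)carbonyl)amino outperforms (4-fluorophenyl)carbamoyl here by a modest margin. Among the compounds shown here, with that orientation kept, two other single changes can now be read on their own, which the earlier compounds did not allow: hydrogen in place of 2-(dimethylamino)ethyl on the side chain of the core gives a 7.0-fold lower number from compound 1 to compound 4 (0.85 log units; beyond the scatter), and 4-fluorophenyl in place of pyridin-4-yl on the carbonyl carbon gives an at least 10-fold lower number from compound 2 to compound 4 (1.00 log units; beyond the scatter). Compound 2 stands at a limit of the assay and not at a number, so this last step gives only a minimum size: the limit of > 20000 nM in this assay, at which 1 of the 4 values shown sits.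

Whether reversing the amide would give a similar gain with the 2-(dimethylamino)ethyl chain in place remains open, as the compounds shown carry that chain with only one amide orientation. On these data alone, it is also open how far the ring on the carbonyl can vary, for example with a plain phenyl, a methoxy group or a carboxylic acid in place of the fluorine.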